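Swapping a Nitrile for Fluorine on the Triazole Aryl Ring

The source may hold more compounds than are shown below. What is called first, only, known or untested is meant among the compounds shown, and "the series" means these compounds.

Measured so far:
- Compound 1, `COc1ccc(/C=C\C(=O)O)c(OCc2cn(-c3ccccc3C(=O)N3CCC(O)C3)nn2)c1CC=C(C)C`: 36200 nM
- Compound 2, `COc1ccc(/C=C\C(=O)O)c(OCc2cn(-c3ccccc3C#N)nn2)c1CC=C(C)C`: "not determined" (no result reported)
- Compound 3, `COc1ccc(/C=C\C(=O)O)c(OCc2cn(-c3ccc(NC(=O)c4ccccc4)cc3)nn2)c1CC=C(C)C`: "not determined" (no result reported)

All three share one core, an acrylic acid bearing a triazole linked through an oxymethyl bridge, and differ only in the aryl group attached to the triazole nitrogen. In a functional assay on PC-3 cells (Homo sapiens) for cytotoxicity, read by MTT assay, with a stated time of 24 h (on this read-out lower numbers stand for stronger inhibition and higher numbers for weaker inhibition), compound 1 gives 36200 nM, a weak effect. In this assay, among the measured compounds shown here, compound 2, carrying a 2-cyanophenyl group, is recorded as "not determined" (no result reported), and compound 3 is recorded as "not determined" (no result reported), so compound 2 cannot be placed relative to compound 1 on the numbers available; the only concrete reading in the set is the one for compound 1.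

The next compound, compound 4, `COc1ccc(/C=C\C(=O)O)c(OCc2cn(-c3ccccc3F)nn2)c1CC=C(C)C`, differs from compound 2 by fluoro in place of cyano on an aromatic carbon. For the measured compounds named here, since no step between measured compounds is known, there is no basis for expecting a shift in this assay in either direction; the working assumption is a value of the same weak order as compound 1. Compound 4 is therefore expected to give roughly 40000 nM, estimated to fall between 10000 nM and 150000 nM, with a real chance that only a limit is reported.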

Compound 4, half-maximal inhibitory concentration: 24200 nM
Compound 4: the middle estimate sits 1.7-fold (0.22 log units) above what was measured, and the stated range covers the measured number.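

In this assay, putting fluoro in place of (3-hydroxypyrrolidin-1-yl)carbonyl on an aromatic carbon gives a 1.5-fold lower number from compound 1 to compound 4 (0.17 log units; within the scatter), so two very different groups at this place on the ring leave the read-out in the same weak range. Among the compounds shown here, this is the first comparison available at this position, and it shows that removing the whole amide-linked ring does not take the effect beyond the usual scatter; the exchange of cyano for fluoro cannot be read, as compound 2 has no number. Nothing shown here explains the result.

Going by these compounds, whether any group at this position can bring the number far down remains open. An amine or a plain methyl group here, for example, could still behave differently from the groups seen so far.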